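The source may report more compounds than this note shows. Statements on the series, on what has been measured and on what is new or still open speak of the compounds shown alone.

Three compounds share a core carrying a long saturated chain and a hydroxy group, and all three were tested in a functional assay on cells (Lymphocyte, Homo sapiens), read by a luciferase reporter and ATP content, with a stated time of 48 h, tested at 20 uM; a lower number here means a stronger effect, a higher number a weaker effect of the compound at the concentration tested. Compound 1, `CCCCCCCCCCCCCCc1nc(OC2CCC2)nc(N2CCC2)c1O`, gives 54%. Compound 2, `CCCCCCCCCCCCCCCCc1nc(OC2CCC2)nc(N2CCC2)c1O`, differs from compound 1 by ethyl in place of hydrogen on a saturated chain carbon, ten or more bonds along the chain from an aromatic carbon, and compound 2 gives 99%; the step is a number 45 percentage points higher from compound 1 to compound 2 (beyond the scatter). Compound 3, `CCCCCCCCCCCCCCc1nc(N2CCC2)nc(N2CCC2)c1O`, differs from compound 1 by azetidin-1-yl in place of cyclobutyloxy on an aromatic carbon, and compound 3 gives 1%; that step is a number 53 percentage points lower from compound 1 to compound 3 (beyond the scatter).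

Compound 4, `CCCCCCCCCCCCCCCCc1nc(N2CCC2)nc(N2CCC2)c1O`, has not yet been measured. It differs from compound 3 by ethyl in place of hydrogen on a saturated chain carbon, ten or more bonds along the chain from an aromatic carbon. For the measured compounds named here, this is the same change as the one from compound 1 to compound 2, made at the same place, but on the core of compound 3 rather than the core of compound 1; the two cores differ by azetidin-1-yl in place of cyclobutyloxy on an aromatic carbon, and nothing shows how that difference interacts with lengthening the chain.

Going by the values given here, the expected step from compound 3 to compound 4 in this assay is a number 29 percentage points higher from compound 3 to compound 4 (beyond the scatter), a weakening in the same direction as the measured step of a number 45 percentage points higher from compound 1 to compound 2 (beyond the scatter), but estimated with wide bounds, since only one such step is known. Compound 4 is estimated at 30%, expected to lie between 3% and 75%.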

Compound 4, a percentage reported as activity, at one concentration (the size of the read-out at that concentration, not a potency): 1%
Beside the measured number, compound 4's estimate is 29 percentage points above it; the whole stated range lies above it.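

In this assay, the chain change does not carry over from one core to the other: ethyl in place of hydrogen on the saturated chain gives no change at the digits printed from compound 3 to compound 4 (within the scatter), unlike the clear rise on the core of compound 1: the same change on two cores in this assay, a number 45 percentage points higher (beyond the scatter) from compound 1 to compound 2 and no change at the digits printed (within the scatter) from compound 3 to compound 4, 45 percentage points apart, beyond the scatter of two such steps

The same result appears when the other change is followed, as azetidin-1-yl in place of cyclobutyloxy gives a number 98 percentage points lower from compound 2 to compound 4 (beyond the scatter), a larger drop on the longer chain than on the shorter one: the same change on two cores in this assay, a number 53 percentage points lower (beyond the scatter) from compound 1 to compound 3 and a number 98 percentage points lower (beyond the scatter) from compound 2 to compound 4, 45 percentage points apart, beyond the scatter of two such steps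

So in these four compounds the two changes do not simply add up, and the effect of lengthening the chain depends on the core, but the numbers do not show why, and a single pair of cores sets no rule for the series.

The compounds shown leave open how a shorter chain, such as a decyl group, would behave on each core. They also leave open whether a group such as methoxy or morpholin-4-yl in place of cyclobutyloxy would follow the core of compound 1 or that of compound 3.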